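This account rests on a few compounds, and the source may have more. Where it says the series, first, only, none or still open, it means among the compounds named here.

Measured so far:
compound 1, `COc1cccc(/C=C2\CCCc3ccccc3C2=O)c1OC` — 8580 nM
compound 2, `O=C1/C(=C/c2ccccc2Cl)Cc2ccccc21` — 26500 nM
compound 3, `O=C1/C(=C/c2ccc(Cl)cc2Cl)Cc2ccccc21` — in a functional assay on P388 cells (Mus musculus) for inhibition (a higher number here means a weaker inhibitor, a lower number a stronger inhibitor), compound 3 gives only the limit > 50000 nM, not a number.

Compound 2 stands at the highest of the two numbers in this assay; its nearest neighbour, compound 1, sits lower. Going by the values given here, the one measured step that starts from compound 2 is an at least 1.8-fold higher number from compound 2 to compound 3 (0.27 log units; that floor lies within the scatter), but it rests on the limit of > 50000 nM in this assay, at which 1 of the 3 values shown sits, and therefore gives no size, only a floor within the scatter.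

Compound 4, `Cc1ccccc1/C=C1\Cc2ccccc2C1=O`, differs from compound 2 by methyl in place of chloro on an aromatic carbon. Among the compounds with values here, no measured step exchanges chloro for methyl, and the only step touching this carbon ends at a limit, so the expectation for compound 4 in this assay is no shift beyond the scatter, a 1.1-fold lower number from compound 2 to compound 4 (0.03 log units; within the scatter). Compound 4 is therefore estimated at 25000 nM, within 9000 nM to 55000 nM.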

Compound 4, half-maximal inhibitory concentration: 23900 nM
Beside the measured number, compound 4's estimate is 1.0-fold (0.02 log units) above it; low and high end bracket the measured number.
By their numbers in this assay, from the lowest: compound 1; then compounds 4 and 2 (each within the scatter of the next). At a limit, above all of these: compound 3.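

In this assay, the exchange gives a 1.1-fold lower number from compound 2 to compound 4 (0.04 log units; within the scatter), so at this aromatic carbon, ortho to a large group, chloro and methyl are not told apart. Going by these compounds alone, this is the first step that can be read for size. Compound 3 carries a limit, not a number, so its step cannot be read for size: the limit of > 50000 nM in this assay, at which 1 of the 4 values shown sits.

From the compounds shown here alone, whether an amine or a carboxylic acid at this carbon would move the number beyond the scatter remains open. So does whether a longer chain there would.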